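Thiophene carboxamide thioureas: bromo to trifluoromethyl swap

The compounds below may be only part of what the source reports. "The series", "measured", "known", "first", "only" and "open" are said of these compounds alone.

Measured so far:
compound 1, `NC(=O)c1c(NC(=O)c2ccccc2Br)sc2c1CCN(C(=S)Nc1ccccc1Cl)C2`, 14600 nM
compound 2, `NC(=O)c1c(NC(=O)c2ccccc2C(F)(F)F)sc2c1CCN(C(=S)Nc1ccccc1Cl)C2`, 17600 nM
compound 3, `Cc1ccccc1C(=O)Nc1sc2c(c1C(N)=O)CCN(C(=S)Nc1ccccc1Br)C2`, 45200 nM

The three compounds were run in a functional assay on HL-60 cells (Homo sapiens) for antiproliferative activity, with a stated time of 24 h; a higher number here means a weaker inhibitor, a lower number a stronger inhibitor. In this assay compound 1 gives 14600 nM and compound 2 gives 17600 nM; the change between them is trifluoromethyl in place of bromo on an aromatic carbon, and the step is a 1.2-fold higher number from compound 1 to compound 2 (0.08 log units; within the scatter). Compound 3 gives 45200 nM, a higher number than either, and that gap lies beyond the scatter in both directions. How the core of compound 3 differs from that of compound 1 is not broken down here.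

Compound 4, `Cc1ccccc1C(=O)Nc1sc2c(c1C(N)=O)CCN(C(=S)Nc1ccccc1C(F)(F)F)C2`, is not yet measured. Relative to compound 3 the change is trifluoromethyl in place of bromo on an aromatic carbon, the same change already seen from compound 1 to compound 2 at the same place on the ring. Since that earlier step stayed within the scatter, a similarly small step is expected here: compound 4 is estimated at 54000 nM, between 25000 nM and 115000 nM, a step of a 1.2-fold higher number from compound 3 to compound 4 (0.08 log units; within the scatter). The estimate rests on compound 3 giving 45200 nM and on the step of a 1.2-fold higher number from compound 1 to compound 2 (0.08 log units; within the scatter).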

Compound 4, half-maximal inhibitory concentration: 23200 nM
Beside the measured number, compound 4's estimate is 2.3-fold (0.37 log units) above it, outside the stated range (below it).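

In this assay, trifluoromethyl in place of bromo on an aromatic carbon gives a 1.9-fold lower number from compound 3 to compound 4 (0.29 log units; within the scatter) and so leaves compound 3 and compound 4 inside the scatter of each other. Set beside the earlier step, the same change shows no difference that can be told apart between the two cores: the same change on two cores in this assay, a 1.2-fold higher number (0.08 log units; within the scatter) from compound 1 to compound 2 and a 1.9-fold lower number (0.29 log units; within the scatter) from compound 3 to compound 4, 2.3-fold (0.37 log units) apart, within the scatter of two such steps. This supports treating the swap as a change of little consequence for this read-out in these two matched pairs, but two pairs with small steps do not show that it would carry the same way to any further core or to another assay.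

As far as these compounds go, whether methoxy, a nitrile or an amine on the same aromatic carbon would take the number beyond the scatter stays open. From the compounds shown here alone, the separate contributions of the places in which compound 1 and compound 3 differ also stay open.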